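A few compounds are considered here, and "the series" means these few. Any claim that something is new, unique, unknown or untested is made for them only; others in the source may bear on it.

Measured so far:
- compound 1 `C=C1[C@H](C)CCC[C@]1(C)CC/C(C)=C/CC1=C(O)C(=O)C=C(N[C@@H](C(=O)O)C(C)C)C1=O` — 6.2 ug/mL
- compound 2 `CC1=CCC[C@](C)(CC/C(C)=C/CC2=C(O)C(=O)C=C(N[C@@H](C(=O)O)[C@@H](C)O)C2=O)[C@@H]1C` — > 10 ug/mL
- compound 3 `CC1=CCC[C@](C)(CC/C(C)=C/CC2=C(O)C(=O)C=C(N[C@@H](CO)C(=O)O)C2=O)[C@@H]1C` — > 10 ug/mL

Within the data shown here, in an ADME assay on KB cells (Homo sapiens) for cytotoxicity, with a stated time of 48 h (on this read-out lower numbers stand for stronger inhibition and higher numbers for weaker inhibition), compound 1 gives 6.2 ug/mL, the only plain number among the three results. For compound 2 the result is a limit of this assay rather than a number, > 10 ug/mL. For compound 3 the result is likewise a limit, > 10 ug/mL. Among the measured compounds shown here, the one step between measured compounds that differ in a single place, a step that the two limits leave unreadable from compound 2 to compound 3, runs between two such limits and so cannot be read.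

Compound 4 `C=C1[C@H](C)CCC[C@]1(C)CC/C(C)=C/CC1=C(O)C(=O)C=C(N[C@H](C(=O)O)[C@@H](C)O)C1=O` has not been measured. It differs from compound 1 in one place: 1-carboxy-2-hydroxypropyl in place of 1-carboxy-2-methylpropyl on an amine nitrogen. For the measured compounds named here, no measured step bears directly on this change. What the data do offer is the limit of > 10 ug/mL in this assay, at which 2 of the 3 values shown sit, and one of the two compounds sitting there, compound 2, carries the same 1-carboxy-2-hydroxypropyl group on an amine nitrogen, though on a different core. Compound 4 is therefore expected to lose inhibition relative to compound 1, with a 1.9-fold higher number from compound 1 to compound 4 (0.29 log units; within the scatter) as the expected step toward the limit. Compound 4 is estimated at 12 ug/mL in this assay. The expected range for compound 4 runs from 5 ug/mL to 30 ug/mL, and a result reported only as a limit would not be surprising.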

Compound 4, half-maximal inhibitory concentration: > 10 ug/mL
Compound 4 ended at the assay's limit; the forecaster's own chance of this, stated with the estimate: 55%; the middle value lies beyond the limit too.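

Among these compounds, on the core of compound 1, 1-carboxy-2-hydroxypropyl in place of 1-carboxy-2-methylpropyl on the amine nitrogen gives an at least 1.6-fold higher number from compound 1 to compound 4 (0.20 log units; that floor lies within the scatter) in this assay, the first comparison of these two groups on one core. On these data alone, since only a floor is known, the real size of the step stays open: it may be small enough to vanish into the usual scatter of repeated measurements, or much larger, so a true loss of inhibition is possible but not proven. The new result also extends a pattern among the four compounds, with no compound going against it: compound 1, whose group on the amine nitrogen has no hydroxyl, is the only one to give a plain number, while all three whose group carries a hydroxyl sit at the same ceiling: the limit of > 10 ug/mL in this assay, at which 3 of the 4 values shown sit.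

The compounds shown leave open whether a plain number would return with a longer carbon chain, such as 1-carboxy-3-methylbutyl, on the amine nitrogen, or whether the carboxylic acid matters, as a methyl ester or primary amide in its place could test. They also cannot separate the effect of the group from that of the core, since the step between the two limits on the other core cannot be read.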